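The compounds below may be only part of what the source reports. "The series", "measured", "known", "first", "only" and "open" are said of these compounds alone.

Of the compounds shown here, three have been measured in an ADME assay on MT4 cells (Homo sapiens) for cytotoxicity, read by MTT assay, with a stated time of 5 days; a higher number here means that more compound is tolerated, a lower number that less compound is tolerated. Compound 1 `Cc1cc(C)c(Oc2cc(Nc3ccc(C#N)cc3)ncc2C(=O)NCc2cn(Cc3ccccc3F)nn2)c(C)c1` gives a value that is only a limit of the assay, > 222000 nM. Compound 3 `Cc1cc(C)c(Oc2cc(Nc3ccc(C#N)cc3)ncc2C(=O)NCc2cn(Cc3cccc(F)c3)nn2)c(C)c1` likewise gives only a limit, >= 204000 nM. Compound 2 `CCOC(=O)Cn1cc(CNC(=O)c2cnc(Nc3ccc(C#N)cc3)cc2Oc2c(C)cc(C)cc2C)nn1`, by contrast, gives a number in this assay, 9530 nM. Within the data shown here, compound 3 therefore stands at the upper edge of what the assay reports, and no step between it and compound 1 can be sized, since a step that the two limits leave unreadable from compound 1 to compound 3.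

Compound 4 `CCOC(=O)CCn1cc(CNC(=O)c2cnc(Nc3ccc(C#N)cc3)cc2Oc2c(C)cc(C)cc2C)nn1` is not yet measured. Its change from compound 3 is (ethoxycarbonyl)methyl in place of 3-fluorophenyl on a saturated chain carbon bound to an aromatic nitrogen; compound 4 thus carries 2-(ethoxycarbonyl)ethyl where compound 2 carries (ethoxycarbonyl)methyl. Among the measured compounds shown here, two measured steps bear on this change. From the 2-fluorophenyl compound there was an at least 23-fold lower number from compound 1 to compound 2 (1.36 log units; beyond the scatter), and in the opposite direction there was an at least 21-fold higher number from compound 2 to compound 3 (1.33 log units; beyond the scatter). Both point the same way: replacing a fluorophenyl by an ester-bearing chain at this position lowered the tolerated concentration by a large margin, and the change to compound 4 is close to the reverse of the second step. A large downward step is therefore expected, an at least 13-fold lower number from compound 3 to compound 4 (1.13 log units; beyond the scatter). Compound 4 is estimated at 15000 nM in this assay, within a range from 3500 nM to 65000 nM.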

Compound 4, half-maximal cytotoxic concentration: 21500 nM
Compound 4: middle estimate off by 1.4-fold (0.16 log units), on the low side, within the range that was stated.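

Compound 4 shows that the lower number at this position is not confined to compound 2, since a second ester-bearing chain also gives one in this assay: there is an at least 9.4-fold lower number from compound 3 to compound 4 (0.97 log units; beyond the scatter), and likewise an at least 10-fold lower number from compound 1 to compound 4 (1.01 log units; beyond the scatter). Among these compounds, it also shows for the first time that the two ester-bearing chains can be told apart, with the 2-(ethoxycarbonyl)ethyl of compound 4 and the (ethoxycarbonyl)methyl of compound 2 separated by a 2.3-fold higher number from compound 2 to compound 4 (0.35 log units; beyond the scatter), a modest step that leaves both far closer to each other than to the fluorophenyl-bearing compounds. Compound 3 gives only a limit of the assay, so the step that starts from it sets a floor and not a size: the limit of >= 204000 nM in this assay, at which 1 of the 4 values shown sits.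

The compounds shown leave open whether the lower number goes with the ester itself or with the loss of the fluorophenyl ring, and whether the rise from compound 2 to compound 4 would continue along the chain. A carboxylic acid in place of the ethyl ester, or a longer chain carrying the same ester, would bear on these two questions.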